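The source may report more compounds than this note shows. Statements on the series, on what has been measured and on what is new or still open speak of the compounds shown alone.

Measured compounds in the series:
- compound 1 `Cc1cc(COc2ccccc2)nc(-c2ccccn2)n1`: 794 nM
- compound 2 `COc1cccc(OCc2cc(C)nc(-c3ccccn3)n2)c1`: 2000 nM
- compound 3 `CC(=O)Nc1ccccc1OCc1cc(C)nc(-c2ccccn2)n1`: > 39800 nM

Compound 1 and compound 2 share the core; in a functional assay on cells for antagonist activity at Free fatty acid receptor 1 (Homo sapiens), read by TR-FRET and inositol phosphate accumulation, with a stated time of 2 h (a lower number here means a stronger inhibitor, a higher number a weaker inhibitor), compound 2 gives 2000 nM, the highest of the two numbers shown, with compound 1 the nearest at 794 nM. That step, a 2.5-fold higher number from compound 1 to compound 2 (0.40 log units; beyond the scatter), is modest and beyond the scatter. Compound 3 gives only a limit in this assay, > 39800 nM, so its number is not known; the step of an at least 50-fold higher number from compound 1 to compound 3 (1.70 log units; beyond the scatter) is large, and it is the only case here in which the limit of > 39800 nM in this assay, at which 1 of the 3 values shown sits, is reached.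

Compound 4 `CC(=O)Nc1cccc(OCc2cc(C)nc(-c3ccccn3)n2)c1` is not yet measured. It differs from compound 2 by acetamido in place of methoxy on an aromatic carbon.

Both measured steps bear on this change. Adding a methoxy to compound 1 cost a modest amount, a 2.5-fold higher number from compound 1 to compound 2 (0.40 log units; beyond the scatter); adding an acetamido to compound 1 cost far more, an at least 50-fold higher number from compound 1 to compound 3 (1.70 log units; beyond the scatter), though at a different place on the ring. Swapping methoxy for acetamido is therefore expected to raise the number in this assay, by a step well beyond the scatter, with a real chance that only a limit is returned.

The estimate for compound 4 in this assay is 10000 nM, between 3000 nM and 40000 nM; the expected step is a 5.0-fold higher number from compound 2 to compound 4 (0.70 log units; beyond the scatter).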

Compound 4, half-maximal inhibitory concentration: > 39800 nM
Compound 4: a limit, no number; the forecaster's own chance of this, stated with the estimate: 30%; middle value at least 3.9-fold (0.59 log units) away from the limit.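

In this assay compound 4 returns only a limit, > 39800 nM, and not a number. Acetamido meta to a large group therefore costs far more than methoxy at that place, an at least 19-fold higher number from compound 2 to compound 4 (1.29 log units; beyond the scatter), and the loss against the unsubstituted ring of compound 1 is just as large, an at least 50-fold higher number from compound 1 to compound 4 (1.70 log units; beyond the scatter); both steps are bounds, and the true gaps may be wider. Compound 3 already showed a large loss with acetamido at another place on the same ring, so the loss no longer belongs to a single place, and among the compounds shown, acetamido at either place ends at the same ceiling: the limit of > 39800 nM in this assay, at which 2 of the 4 values shown sit.

Going by these compounds, compound 3 and compound 4 both stand at a limit, so they cannot be ordered, and the effect of moving the acetamido around the ring stays unknown in this assay. On these data alone, it also stays open whether a small amine, a hydroxyl or a fluorine at the place held by acetamido in compound 4 would keep a measurable value, or whether an N-methyl acetamido or a carboxylic acid there would end at the same limit.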